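Three Measured Analogues and One Aromatic Group Exchanged

The compounds below may be only part of what the source reports. "The series", "measured", "known", "first", "only" and "open" are said of these compounds alone.

compound 1 `CC(C(=O)N1CCN(c2ccccc2C(F)(F)F)CC1)N1C(=O)CCC1=O`: 75%
compound 2 `CCC(C(=O)N1CCN(c2ccccc2F)CC1)N1C(=O)CCC1=O`: 0%
compound 3 `COc1cccc(N2CCN(C(=O)C(C)N3C(=O)CCC3=O)CC2)c1`: 0%

All three numbers come from a functional assay on the whole organism (strain Swiss) with Mus musculus as the target, in the maximal electroshock model, with a stated time of 2 h, at a dose of 300 mg/kg by the intraperitoneal route; on this read-out higher numbers stand for a stronger effect at the one dose given and lower numbers for a weaker effect. Compound 1 gives 75% in this assay, the highest of the three. Compound 2 gives 0% and compound 3 gives 0%; these two are level with each other within the scatter and together form the bottom of the set, with compound 1 standing a long way above compound 3, beyond the scatter.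

The step of interest leads from compound 3 to the unmeasured compound 4 `CC(C(=O)N1CCN(c2ccc(Cl)cc2)CC1)N1C(=O)CCC1=O`. For the measured compounds named here, the only change is 4-chlorophenyl in place of 3-methoxyphenyl on an amine nitrogen in a ring. Going by the values given here, no measured pair differs in one place alone, so there is no directly comparable step to lean on. What the data do show is that the aromatic group matters: compound 1 and compound 3 share the same remaining framework yet sit far apart. An exchange of this aromatic group could therefore move the number in either direction, and a sizeable upward step is expected as plausible, though a result staying level with compound 3 cannot be ruled out.

Taking the middle of that wide spread, compound 4 is estimated to give 50%, with a range from 0% to 100% in this assay. This estimate means an expected step of a number 50 percentage points higher from compound 3 to compound 4 (beyond the scatter).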

Compound 4, a percentage reported as activity, at one dose (the size of the read-out at that dose, not a potency): 0%
Estimate against measurement, compound 4: 50 percentage points above; measured number inside the range.
By their numbers in this assay, from the lowest: compounds 2, 3 and 4 (each within the scatter of the next); then compound 1.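

In this assay, for the compounds shown here, putting 4-chlorophenyl in place of 3-methoxyphenyl on an amine nitrogen in a ring brings no change at the digits printed from compound 3 to compound 4 (within the scatter) and gives the first step at this position that can be read directly. Going by these compounds alone, it shows that changing the aromatic group does not by itself raise the number: two groups that differ in their substituent and in where it sits on the ring leave the read-out in the same place, while compound 1 gives 75% as the only clearly active compound of the set. Nothing measured here explains why this exchange leaves the read-out unmoved.

From the compounds shown here alone, what sets the aromatic group of compound 1 apart from those of compound 3 and compound 4 remains open, since a single step between two inactive compounds cannot separate the identity of a substituent from its place on the ring. A plain phenyl group, or a phenyl ring carrying a nitrile or a carboxylic acid, would be needed to show how much of this position's range is reached by other groups.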